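From Triazole to Methanesulfonamido: An Expected Cytotoxicity Step

The compounds below may be only part of what the source reports. "The series", "measured", "known", "first", "only" and "open" are said of these compounds alone.

Values in an ADME assay on HEK293-A cells (Homo sapiens) for cytotoxicity, read by MTT assay, with a stated time of 48 h; a lower number here means a stronger inhibitor, a higher number a weaker inhibitor:
- compound 1 `O=C(OC[C@H]1CN(c2ccc(-n3cc(-c4ccccn4)cn3)c(F)c2)C(=O)O1)c1ccccc1`: > 400 ug/mL (a limit)
- compound 2 `O=C1O[C@@H](Cn2ccnn2)CN1c1ccc(-n2cc(-c3ccccn3)cn2)c(F)c1`: 225 ug/mL

Among the measured compounds shown here, compound 2 stands at 225 ug/mL, the only exact number so far. Compound 1 gives > 400 ug/mL, which is a limit of the assay and not a number.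

The next molecule, compound 3 `CS(=O)(=O)NC[C@H]1CN(c2ccc(-n3cc(-c4ccccn4)cn3)c(F)c2)C(=O)O1`, carries methanesulfonamido in place of 1H-1,2,3-triazol-1-yl on a saturated chain carbon bound to a saturated ring carbon. One measured step changes a group at this same place: an at least 1.7-fold lower number from compound 1 to compound 2 (0.24 log units; that floor lies within the scatter). Because an at least 1.7-fold lower number from compound 1 to compound 2 (0.24 log units; that floor lies within the scatter) offers only a floor within the scatter, no step beyond the scatter is expected in this assay. The expected change is a 1.1-fold higher number from compound 2 to compound 3 (0.05 log units; within the scatter). For compound 3 the estimated value is 250 ug/mL, with an expected range of 125 ug/mL to 400 ug/mL.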

Compound 3, half-maximal inhibitory concentration: 314 ug/mL
Beside the measured number, compound 3's estimate is 1.3-fold (0.10 log units) below it; low and high end bracket the measured number.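

At this place, on a saturated chain carbon bound to a saturated ring carbon, a ring in the substituent turns out not to matter for the reading in this assay: replacing 1H-1,2,3-triazol-1-yl with methanesulfonamido, which has no ring, gives a 1.4-fold higher number from compound 2 to compound 3 (0.14 log units; within the scatter), so these two groups cannot be told apart here. The comparison with benzoyloxy gives only a floor, an at least 1.2-fold lower number from compound 1 to compound 3 (0.10 log units; that floor lies within the scatter). That comparison stays open-ended because compound 1 sits at a limit of the assay and not at a number: the limit of > 400 ug/mL in this assay, at which 1 of the 3 values shown sits.

Going by these compounds, it remains open whether a group of another kind at this place, such as a primary amine or a carboxylic acid, would move the number beyond the scatter. On these data alone, it is equally open whether a longer chain carrying methanesulfonamido would read the same as compound 3.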